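Methoxy to ethoxy on the shared core

The source may hold more compounds than are shown below. What is called first, only, known or untested is meant among the compounds shown, and "the series" means these compounds.

Values in a functional assay on MCF7 cells (Homo sapiens) for antiproliferative activity, read by sulforhodamine B assay, with a stated time of 72 h; a higher number here means a weaker inhibitor, a lower number a stronger inhibitor:
- compound 1 `O=C(/C=C/c1csc2ccccc12)c1ccccc1O`: 6600 nM
- compound 2 `O=C(/C=C/c1csc2ccccc12)c1cc(F)ccc1O`: > 10000 nM
- compound 3 `COc1ccc(O)c(C(=O)/C=C/c2csc3ccccc23)c1`: 750 nM

Compound 2 gives only a limit, > 10000 nM. Of the two true numbers, compound 3 holds the lower, 750 nM. Methoxy brought an 8.8-fold lower number from compound 1 to compound 3 (0.94 log units; beyond the scatter), a modest step beyond the scatter, and an at least 13-fold lower number from compound 2 to compound 3 (1.12 log units; beyond the scatter). Fluoro gave an at least 1.5-fold higher number from compound 1 to compound 2 (0.18 log units; that floor lies within the scatter). Compound 4 `CCOc1ccc(O)c(C(=O)/C=C/c2csc3ccccc23)c1` carries methyl in place of hydrogen on a saturated chain carbon bound to an oxygen on an aromatic ring, turning methoxy to ethoxy. Going by the values given here, no measured step alters the methoxy group itself. The gain in an 8.8-fold lower number from compound 1 to compound 3 (0.94 log units; beyond the scatter) is expected to survive largely intact, so no step beyond the scatter is expected in this assay. The expected change is a 1.2-fold higher number from compound 3 to compound 4 (0.08 log units; within the scatter). For compound 4 the estimated value is 900 nM, with an expected range of 300 nM to 2700 nM.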

Compound 4, half-maximal inhibitory concentration: 7500 nM
Compound 4: middle estimate off by 8.3-fold (0.92 log units), on the low side; measured number outside the range, above it.
By their numbers in this assay, from the lowest: compound 3; then compounds 1 and 4 (each within the scatter of the next). At a limit, above all of these: compound 2.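

In this assay, the gain seen with methoxy does not carry over to ethoxy: methyl in place of hydrogen on this saturated chain carbon gives a 10-fold higher number from compound 3 to compound 4 (1.00 log units; beyond the scatter). None of that gain remains, with a 1.1-fold higher number from compound 1 to compound 4 (0.06 log units; within the scatter). The remaining step, an at least 1.3-fold lower number from compound 2 to compound 4 (0.12 log units; that floor lies within the scatter), starts from a limit and gives only a floor: the limit of > 10000 nM in this assay, at which 1 of the 4 values shown sits.

As far as these compounds go, whether the loss continues with a longer chain such as propoxy remains open. So does how a hydroxy group or an amine would fare at this place.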